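The compounds below may be only part of what the source reports. "The series", "measured", "known", "first", "only" and "open" are said of these compounds alone.

Three compounds share one core, and only one of them has a number. Compound 1 `c1ccc(CNc2ccc3nc(-c4ccccc4)oc3n2)cc1` was entered in an assay on isolated protein for inhibition of Amine oxidase [flavin-containing] B (Homo sapiens), read by fluorescence, with a stated time of 1 h (a higher number here means a weaker inhibitor, a lower number a stronger inhibitor), where compound 1 gives "not determined" (no result reported). Compound 2 `c1ccc(-c2nc3ccc(N4CCCCCC4)nc3o2)cc1` was entered in this assay too, and compound 2 gives "not determined" (no result reported). Neither of them offers a foothold. Compound 3 `Fc1ccccc1-c1nc2ccc(N3CCCCC3)nc2o1` is the single anchor: in this assay compound 3 gives 665 nM. It therefore stands alone, neither high nor low by comparison, simply the one measured point.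

Compound 4 `Clc1cccc(-c2nc3ccc(N4CCCCC4)nc3o2)c1` is the next compound to be tested in this assay. It differs from compound 3 in one place: 3-chlorophenyl in place of 2-fluorophenyl on an aromatic carbon. Both halogenated phenyl rings sit on the same carbon of the shared core; what changes is the halogen and where it sits on that ring, 3-chlorophenyl in place of 2-fluorophenyl on an aromatic carbon.

Among the measured compounds shown here, with no pair of measured compounds to show how such a swap has behaved here, the expectation rests on compound 3 alone. A swap of one halogenated phenyl for another is expected to move the number little, if at all, beyond the scatter; the estimated step from compound 3 to compound 4 is a 1.5-fold lower number from compound 3 to compound 4 (0.17 log units; within the scatter), leaning slightly toward the stronger side. Compound 4 is thus expected to give about 450 nM in this assay, with a likely range from 120 nM to 1800 nM.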

Compound 4, half-maximal inhibitory concentration: 335 nM
For compound 4 the middle estimate is 1.3-fold (0.13 log units) above the measured one, and the stated range covers the measured number.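

In this assay, putting 3-chlorophenyl in place of 2-fluorophenyl on this aromatic carbon of the five-membered ring gives a 2.0-fold lower number from compound 3 to compound 4 (0.30 log units; within the scatter), a step that lies within the usual scatter of repeated measurements, so the two compounds cannot be ranked against each other. Among the compounds shown here, this is the first pair with two numbers, and it shows that the halogen and its place on the phenyl ring can both change here with no difference that can be told from that scatter, although a swap that alters both at once cannot show what either alteration does alone. No measured information bearing on this result is available to explain it.

As far as these compounds go, whether the number would stay in this range with a plain phenyl, a methoxy group or a carboxylic acid on the phenyl ring, or with an amine or a longer chain at this position, remains open. From the compounds shown here alone, compound 1 and compound 2 offer no number, so any steps involving them cannot be read, and the effect of changing the other substituent on the shared core also remains unknown.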